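The source may report more compounds than this note shows. Statements on the series, on what has been measured and on what is new or still open speak of the compounds shown alone.

Compound 2, `CCCCCCCCCCCCNC(=O)[C@@H](NC(=O)c1cccs1)[C@@H](C)O`, is one of three analogues of the same core that have been tested in a functional assay on HepG2 cells (Homo sapiens) for cytotoxicity, read by MTT assay, with a stated time of 48 h; a lower number here means a stronger inhibitor, a higher number a weaker inhibitor. In this assay compound 2 gives 30100 nM. Its companion compound 3, `CCCCCCCCCCCCNC(=O)[C@@H](NS(=O)(=O)c1ccc(C)cc1)[C@@H](C)O`, gives 25800 nM; the two numbers differ by a 1.2-fold lower number from compound 2 to compound 3 (0.07 log units; within the scatter), so neither can be set apart from the other. Compound 1, `CCCCCCCCCCCCNC(=O)[C@@H](NC(=O)c1ccccc1)[C@@H](C)O`, gives only a limit of the assay in this assay, > 400000 nM. Against that limit the move from the phenyl to the thiophen-2-yl of compound 2 is an at least 13-fold lower number from compound 1 to compound 2 (1.12 log units; beyond the scatter), and the move to the sulfonyl of compound 3 is an at least 15-fold lower number from compound 1 to compound 3 (1.19 log units; beyond the scatter). Compound 2 therefore stands as the higher of the two numbers that are numbers at all, though only within the scatter of compound 3.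

Compound 4, `CCCCCCCCCCCCCCCCCCNC(=O)[C@@H](NC(=O)c1cccs1)[C@@H](C)O`, differs from compound 2 in one place: hexyl in place of hydrogen on a saturated chain carbon, ten or more bonds along the chain from an amide-type nitrogen. For the measured compounds named here, none of the measured steps touches this chain; all three alter the group on the amine nitrogen, so none bears directly on the change. With nothing to point either way, compound 4 is expected to sit near compound 2, the step from compound 2 to compound 4 being estimated as a 1.2-fold lower number from compound 2 to compound 4 (0.08 log units; within the scatter). The estimate for compound 4 in this assay is 25000 nM, with a range from 7000 nM to 90000 nM.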

Compound 4, half-maximal inhibitory concentration: 92000 nM
Estimate against measurement, compound 4: 3.7-fold (0.57 log units) below; the measured number lies above the stated range.
By their numbers in this assay, from the lowest: compounds 3 and 2 (each within the scatter of the next); then compound 4. At a limit, above all of these: compound 1.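

In this assay, the chain proves to be a position that matters: hexyl in place of hydrogen, on a saturated chain carbon, gives a 3.1-fold higher number from compound 2 to compound 4 (0.49 log units; beyond the scatter). The earlier steps shown here all altered the group on the amine nitrogen, so they said nothing about the chain; this step shows that a change far along it moves the number beyond the scatter, modestly and towards a weaker inhibitor, with the thiophen-2-yl carbonyl group left as it was. Nothing shown explains why the added hexyl has this effect, and no measurement given here bears on the cause.

This single pair cannot show whether the same change would act alike with the (4-methylphenyl)sulfonyl group of compound 3 or the benzoyl group of compound 1 on the amine nitrogen. It also leaves open whether the number climbs steadily with chain length, and what a shorter chain, a longer chain, or an amine or a carboxylic acid in place of the hexyl would give.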